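A few compounds are considered here, and "the series" means these few. Any claim that something is new, unique, unknown or untested is made for them only; others in the source may bear on it.

Two related compounds have been measured so far in an ADME assay on the whole organism (plasma) for pharmacokinetics, with Rattus norvegicus as the target, read by LC-MS; on this read-out higher numbers stand for fast clearance and lower numbers for slow clearance. Compound 1 `Cc1cc(C(=O)N[C@H]2CCCCC/C=C\[C@@H]3C[C@@]3(C(=O)NS(=O)(=O)C3CC3)NC(=O)[C@@H]3C[C@@H](Oc4nc5ccccc5nc4C(F)(F)F)CN3C2=O)no1` gives 3.5 mL/min/kg, while compound 2 `Cc1cc(C(=O)N[C@H]2CCCCC/C=C\[C@@H]3C[C@@]3(C(=O)NS(=O)(=O)C3CC3)NC(=O)[C@@H]3C[C@@H](Oc4nc5cc(F)ccc5nc4C(F)(F)F)CN3C2=O)no1` gives 38.3 mL/min/kg, the higher of the two numbers. Within the data shown here, the one measured step between them is an 11-fold higher number from compound 1 to compound 2 (1.04 log units; beyond the scatter), a large step beyond the scatter that goes with fluoro in place of hydrogen on an aromatic carbon.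

Compound 3 `Cc1cc(C(=O)N[C@H]2CCCCC/C=C\[C@@H]3C[C@@]3(C(=O)NS(=O)(=O)C3(C)CC3)NC(=O)[C@@H]3C[C@@H](Oc4nc5cc(F)ccc5nc4C(F)(F)F)CN3C2=O)no1` keeps that fluoro and differs from compound 2 elsewhere: methyl in place of hydrogen on a saturated ring carbon. This is methyl in place of hydrogen on a saturated ring carbon, which turns cyclopropylsulfonyl into (1-methylcyclopropyl)sulfonyl. Among the measured compounds shown here, no measured step covers this change, and the fluoro step lies at another place in the structure, so it gives no direction here. The expectation in this assay is therefore no shift beyond the scatter. The range stays wide because an 11-fold higher number from compound 1 to compound 2 (1.04 log units; beyond the scatter) shows how far a single small change can move these numbers. The estimated step is a 1.3-fold lower number from compound 2 to compound 3 (0.11 log units; within the scatter). The estimate for compound 3 is 30 mL/min/kg, with an expected range of 11 mL/min/kg to 70 mL/min/kg.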

Compound 3, clearance: 26.7 mL/min/kg
For compound 3 the middle estimate is 1.1-fold (0.05 log units) above the measured one, and the stated range covers the measured number.
By their numbers in this assay, from the lowest: compound 1; then compounds 3 and 2 (each within the scatter of the next).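

Putting a methyl on the saturated ring carbon, which turns cyclopropylsulfonyl into (1-methylcyclopropyl)sulfonyl, gives a 1.4-fold lower number from compound 2 to compound 3 (0.16 log units; within the scatter) in this assay, so the two compounds cannot be told apart on this read-out. This place on the three-membered ring therefore accepts one added carbon with no change that stands out from the scatter, whereas the earlier change on an aromatic carbon gave an 11-fold higher number from compound 1 to compound 2 (1.04 log units; beyond the scatter); across these two steps, then, a small change does not carry the same weight at every place in the molecule. No measurement shown here offers an explanation for this result.

Going by these compounds, what the same methyl would do on the core of compound 1, which lacks the fluoro and has a much lower clearance number than compound 2, remains open, as a step seen in one compound need not repeat in another. On these data alone, it is also open whether this ring carbon would accept something larger or different in kind, such as an ethyl group or an amine, with equally little effect on the number.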